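The compounds below may be only part of what the source reports. "The series", "measured", "known", "first", "only" and "open" are said of these compounds alone.

Working notes on the series in an ADME assay on MT2 cells (Homo sapiens) for cytotoxicity, read by XTT assay, with a stated time of 4 days; a lower number here means that less compound is tolerated, a higher number that more compound is tolerated. Compound 3 (`CC(=O)/C=C/c1cc(C)c(Oc2cc(Nc3ccc(C#N)cc3)c([N+](=O)[O-])cc2[N+](=O)[O-])c(C)c1`) gives > 100000 nM, which is a limit of the assay and not a number. Compound 1 (`Cc1cc(/C=C/C#N)cc(C)c1Oc1ccc([N+](=O)[O-])c(Nc2ccc(C#N)cc2)n1`), which carries 2-cyanoethenyl, gives > 100000 nM, also a limit. Compound 2 (`Cc1cc(/C=C/C#N)cc(C)c1Oc1ccc([N+](=O)[O-])c(Nc2ccc(C#N)cc2)c1`), which carries the same group, gives > 100000 nM, again a limit. Compound 3 therefore has no numerical position in the series, and the whole set reads as the limit of > 100000 nM in this assay, at which 3 of the 3 values shown sit.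

Compound 4 (`Cc1cc(/C=C/C#N)cc(C)c1Oc1cc(Nc2ccc(C#N)cc2)c([N+](=O)[O-])cc1[N+](=O)[O-]`) changes compound 3 in one place, 2-acetylethenyl to 2-cyanoethenyl: cyano in place of acetyl on a double-bonded chain carbon bound to a double-bonded chain carbon. Among the measured compounds shown here, no step between measured compounds is available to size this change. The expected step of a number no higher from compound 3 to compound 4 (the limit leaves the size open) is none beyond the scatter, in either direction, and a further limit is the most likely report, because of the limit of > 100000 nM in this assay, at which 3 of the 3 values shown sit. For compound 4 the estimate is 100000 nM, with an expected range from 30000 nM to 100000 nM.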

Compound 4, half-maximal cytotoxic concentration: 21700 nM
Beside the measured number, compound 4's estimate is 4.6-fold (0.66 log units) above it; the whole stated range lies above it.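

In this assay, among the compounds shown here, the change from 2-acetylethenyl to 2-cyanoethenyl gives an at least 4.6-fold lower number from compound 3 to compound 4 (0.66 log units; beyond the scatter), the first reading that is a number and not a limit. Nitro in place of hydrogen on an aromatic carbon gives an at least 4.6-fold lower number from compound 2 to compound 4 (0.66 log units; beyond the scatter), so the lower number appears only where 2-cyanoethenyl and the added nitro occur together, in compound 4. The full size of neither step can be read, because both start from a limit: the limit of > 100000 nM in this assay, at which 3 of the 4 values shown sit.

On these data alone, how far the values would fall with other groups in these places remains open, for example an amine in place of the added nitro or a carboxylic acid in place of the cyano. Also open, as far as these compounds go, is whether a longer chain carrying the cyano would keep the value of compound 4, 21700 nM.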